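This account rests on a few compounds, and the source may have more. Where it says the series, first, only, none or still open, it means among the compounds named here.

Compound 1 `OCc1cn(Cc2ccc(Cl)cc2)c2ccccc12`: > 31600 nM
Compound 2 `COc1ccc2c(c1)c(CO)cn2Cc1ccc(Cl)cc1`: > 31600 nM
Compound 3 `COC(=O)CNCc1cn(Cc2ccc(Cl)cc2)c2ccccc12`: not yet measured

In an ADME assay on T29 cells (Homo sapiens) for cytotoxicity, read by sulforhodamine B assay, with a stated time of 3 days (a higher number here means a weaker inhibitor, a lower number a stronger inhibitor), compound 1 gives > 31600 nM, which is a limit and not a number. Compound 2 gives > 31600 nM, which is also a limit. Neither compound therefore has a measured potency, and both sit at the limit of > 31600 nM in this assay, at which 2 of the 2 values shown sit.

The change to compound 3 is ((methoxycarbonyl)methyl)amino in place of hydroxy on a saturated chain carbon bound to an aromatic carbon. Going by the values given here, the only measured step is a step that the two limits leave unreadable from compound 1 to compound 2, for methoxy in place of hydrogen on an aromatic carbon. That step involves a different change and has no readable size, so it gives no measure for this one. With so little to go on, only a modest shift is expected in this assay, towards a lower number and a stronger inhibitor, and compound 3 may well remain at the limit. The expected step is an at least 1.2-fold lower number from compound 1 to compound 3 (0.10 log units; that floor lies within the scatter). For compound 3 the estimated value is 25000 nM, with an expected range from 8000 nM to 60000 nM.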

Compound 3, half-maximal inhibitory concentration: 31600 nM
Estimate against measurement, compound 3: 1.3-fold (0.10 log units) below, within the range that was stated.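

In this assay, going by these compounds alone, compound 3 gives 31600 nM, the only true number among the three compounds, and so the only one that shows a measurable cytotoxic effect rather than a limit. Placing ((methoxycarbonyl)methyl)amino in place of hydroxy on a saturated chain carbon bound to an aromatic carbon gives a number no higher from compound 1 to compound 3 (the limit leaves the size open), which shows that this position tolerates a group of 6 heavy atoms where 1 stood, but does not show how much the number moves. The other two compounds remain at a limit of the assay, which is not a number, and no step in the series can be read for size: the limit of > 31600 nM in this assay, at which 2 of the 3 values shown sit.

The compounds shown leave open which part of the new group carries the result: a carboxylic acid in place of the methyl ester, a plain amine at this place, or a longer chain carrying the ester could each separate the contributions. They also leave open whether the methoxy group of compound 2 would alter the reading if combined with the ((methoxycarbonyl)methyl)amino group.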